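A Fluorine Added to the Benzyloxy Arm of Compound 2

The source may report more compounds than this note shows. Statements on the series, on what has been measured and on what is new or still open speak of the compounds shown alone.

Compound 2 `O=C(NOCc1ccccc1)c1cn(-c2ccccc2)nc1-c1ccc(F)cc1` holds the highest of the two numbers recorded here. In a functional assay on A549 cells (Homo sapiens) for antiproliferative activity, read by MTT assay, with a stated time of 48 h, in the presence of a further agent that is not named here (a lower number here means a stronger inhibitor of growth, a higher number a weaker inhibitor of growth), compound 2 gives 10400 nM, whereas compound 1 `COc1ccc(-c2nn(-c3ccccc3)cc2C(=O)NOCc2ccccc2F)cc1` gives 2160 nM, a gap that lies beyond the usual scatter. Compound 3 `O=C(NOCc1ccccc1F)c1cn(-c2ccccc2)nc1-c1ccc(F)cc1` differs from compound 2 in one place: fluoro in place of hydrogen on an aromatic carbon, so that benzyloxy becomes (2-fluorobenzyl)oxy. Within the data shown here, no measured pair isolates this change, so its effect in this assay is unknown. One expects only a modest step toward a lower number, near the edge of the scatter, estimated as a 1.7-fold lower number from compound 2 to compound 3 (0.24 log units; within the scatter). Compound 3 is estimated at 6000 nM, with a range from 2500 nM to 15000 nM.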

Compound 3, concentration for 50% growth inhibition: 17500 nM
For compound 3 the middle estimate is 2.9-fold (0.46 log units) below the measured one; measured number outside the range, above it.
By their numbers in this assay, from the lowest: compound 1; then compounds 2 and 3 (each within the scatter of the next).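

Fluoro on the benzyloxy arm, ortho to a large group, gives a 1.7-fold higher number from compound 2 to compound 3 (0.23 log units; within the scatter), so (2-fluorobenzyl)oxy shows no gain over benzyloxy in this series. With (2-fluorobenzyl)oxy kept in place, the aromatic carbon that bears methoxy proves the more telling site: fluoro in place of methoxy gives an 8.1-fold higher number from compound 1 to compound 3 (0.91 log units; beyond the scatter). Nothing available explains either result. Going by these compounds, whether chloro or methyl on the benzyl ring would differ from fluoro remains open. So does the effect of an amine or a hydroxyl in place of methoxy.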